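Swapping a fluoro for a carbamoyl on a cyclopentyl core

This account rests on a few compounds, and the source may have more. Where it says the series, first, only, none or still open, it means among the compounds named here.

Compound 1 `Fc1ccc(-c2nc3cccnc3n2C2CCCC2)cc1` carries a fluoro on its pendant phenyl ring. In a functional assay on MDA-MB-231 cells (Homo sapiens) for cytotoxicity, read by MTT assay, with a stated time of 24 h (a higher number here means a weaker inhibitor, a lower number a stronger inhibitor), compound 1 gives 500 nM, the lower of the two numbers recorded. Compound 2 `Fc1cc(F)cc(C2Nc3cccnc3N2C2CCCC2)c1`, which differs from it in several places, gives 2100 nM in this assay, a gap that lies beyond the usual scatter; nothing more can be read from these two values alone.

Compound 3 `NC(=O)c1ccc(-c2nc3cccnc3n2C2CCCC2)cc1` is the next member. The change from compound 1 is carbamoyl in place of fluoro on an aromatic carbon, on an aromatic carbon of a six-membered aromatic ring of carbon only, para to a large group. Going by the values given here, no measured pair shows this move, so the size of the step is open. A modest weakening, at the edge of the scatter, is expected from compound 1 to compound 3, written as a 1.6-fold higher number from compound 1 to compound 3 (0.20 log units; within the scatter). Compound 3 is therefore estimated at 800 nM in this assay, within 250 nM to 2500 nM.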

Compound 3, half-maximal inhibitory concentration: 8000 nM
Estimate against measurement, compound 3: 10-fold (1.00 log units) below; measured number outside the range, above it.
By their numbers in this assay, from the lowest: compound 1; then compound 2; then compound 3.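

Carbamoyl in place of fluoro on an aromatic carbon, para to a large group, is the first change in a single place on this core, and in this assay it gives a 16-fold higher number from compound 1 to compound 3 (1.20 log units; beyond the scatter) as a large step. The earlier compounds shown here could not show this, and the pair now shows that the number at this position depends strongly on the group it carries, with carbamoyl giving a far higher number than fluoro. No measurement at hand gives a reason for this step.

Going by these compounds, whether a nitrile, a carboxylic acid or an amine at this same place would stay near compound 1 or rise towards compound 3 remains open. Also open, on these data alone, is whether the same swap would give a step of similar size on the core of compound 2.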